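A few compounds are considered here, and "the series" means these few. Any claim that something is new, unique, unknown or untested is made for them only; others in the source may bear on it.

Measured so far:
compound 1 `Cn1c(-c2ccc(NC(=O)CSc3nc4ccccc4s3)cc2)nc(-c2ccccc2)c1-c1ccccc1`: 47.2% in a functional assay on HT-29 cells (Homo sapiens) for cytotoxicity, read by MTT assay, with a stated time of 24 h, tested at 16 ug/mL; a lower number here means a weaker effect, a higher number a stronger effect of the compound at the concentration tested
compound 2 `Cn1cnnc1SCC(=O)Nc1ccc(-c2nc(-c3ccccc3)c(-c3ccccc3)n2C)cc1`: 59.1% in this assay

Compound 2 stands highest of the two numbers; the nearest is compound 1, and the step of a number 11.9 percentage points higher from compound 1 to compound 2 (beyond the scatter) lies beyond the scatter. Compound 3 `Cc1nnc(SCC(=O)Nc2ccc(-c3nc(-c4ccccc4)c(-c4ccccc4)n3C)cc2)s1` differs from compound 2 by 5-methyl-1,3,4-thiadiazol-2-yl in place of 4-methyl-4H-1,2,4-triazol-3-yl on a sulfur. Among the measured compounds shown here, the only measured step that exchanges the ring on that sulfur is a number 11.9 percentage points higher from compound 1 to compound 2 (beyond the scatter), a modest rise, but it involves a different pair of rings and bears on this change only loosely. No step beyond the scatter is therefore expected. In this assay compound 3 is estimated at 55%, within 40% to 70%. The expected step is a number 4.1 percentage points lower from compound 2 to compound 3 (within the scatter).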

Compound 3, a percentage reported as activity, at one concentration (the size of the read-out at that concentration, not a potency): 83.3%
Beside the measured number, compound 3's estimate is 28.3 percentage points below it; measured number outside the range, above it.
By their numbers in this assay, from the lowest: compound 1; then compound 2; then compound 3.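

In this assay the ring on the sulfur matters even when the counts stay the same: 5-methyl-1,3,4-thiadiazol-2-yl and 4-methyl-4H-1,2,4-triazol-3-yl have equal heavy atoms and hetero atoms, yet the exchange gives a number 24.2 percentage points higher from compound 2 to compound 3 (beyond the scatter). Replacing 1,3-benzothiazol-2-yl with 5-methyl-1,3,4-thiadiazol-2-yl gives a number 36.1 percentage points higher from compound 1 to compound 3 (beyond the scatter). No measurement at hand accounts for either rise. As far as these compounds go, whether the methyl on the thiadiazole ring contributes remains open, and an amine or an ethyl in its place would test this.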